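The source may hold more compounds than are shown below. What is called first, only, known or untested is meant among the compounds shown, and "the series" means these compounds.

Measured compounds:
- compound 1 `Cc1cccc(-n2nncc2CN2C(=O)C3(C(C#N)=C(N)Oc4c3c3nc5ccccc5nc3c3ccccc43)c3ccccc32)c1`: 39600 nM
- compound 2 `CC(=O)Nc1ccc(-n2nncc2CN2C(=O)C3(C(C#N)=C(N)Oc4c3c3nc5ccccc5nc3c3ccccc43)c3ccccc32)cc1`: > 50000 nM

In a functional assay on A549 cells (Homo sapiens) for antiproliferative activity, read by MTT assay, with a stated time of 48 h (a lower number here means a stronger inhibitor, a higher number a weaker inhibitor), compound 1 gives 39600 nM. Compound 2 reaches only a limit of the assay, > 50000 nM. For the measured compounds named here, the one measured step, an at least 1.2-fold higher number from compound 1 to compound 2 (0.10 log units; that floor lies within the scatter), sits at the scatter floor and rests on (the limit of > 50000 nM in this assay, at which 1 of the 2 values shown sits). Compound 3 `Cc1ccc(-n2nncc2CN2C(=O)C3(C(C#N)=C(N)Oc4c3c3nc5ccccc5nc3c3ccccc43)c3ccccc32)cc1Cl` differs from compound 2 by 3-chloro-4-methylphenyl in place of 4-acetamidophenyl on an aromatic nitrogen. No measured step sizes this change, and compound 2 itself is known only as a limit, so no step beyond the scatter is expected. Compound 3 is therefore estimated at about 45000 nM, between 15000 nM and 150000 nM, which means an expected step of an at least 1.1-fold lower number from compound 2 to compound 3 (0.04 log units; that floor lies within the scatter).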

Compound 3, half-maximal inhibitory concentration: > 50000 nM
Compound 3 gave a limit, no number; the forecaster's own chance of this, stated with the estimate: 50%; at least 1.1-fold (0.04 log units) between middle value and limit.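

In this assay compound 3 gives > 50000 nM, a limit and not a number, so a phenyl group with no hydrogen-bond donor or acceptor ends at the same limit as 4-acetamidophenyl. Set against 3-methylphenyl, the 3-chloro-4-methylphenyl group gives an at least 1.2-fold higher number from compound 1 to compound 3 (0.10 log units; that floor lies within the scatter), while the step between compound 2 and compound 3 cannot be read. This position so far shows a ceiling and not a trend: the limit of > 50000 nM in this assay, at which 2 of the 3 values shown sit.

Going by these compounds, whether any group on this aromatic nitrogen can bring the number well under that limit stays open. An amine or a carboxylic acid on the phenyl ring, or a longer alkyl chain in its place, would test this.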